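Removing the fluoro group from compound 1

The compounds below may be only part of what the source reports. "The series", "measured", "known", "first", "only" and "open" are said of these compounds alone.

In a functional assay on PC-3 cells (Homo sapiens) for antiproliferative activity, read by MTT assay, with a stated time of 72 h (a lower number here means a stronger inhibitor, a higher number a weaker inhibitor), compound 1 (`O=C(N/N=C/c1ccccc1)Nc1ccc(Oc2ccnc3[nH]ccc23)c(F)c1`) gives 7940 nM, the lower of the two numbers available in this small set. Its nearest neighbour, compound 3 (`O=C(N/N=C/c1ccc(O)c(Br)c1)Nc1ccc(Oc2ccnc3[nH]ccc23)c(F)c1`), gives 28600 nM. Compound 2 (`O=C(N/N=C/c1cccc(Cl)c1Cl)Nc1ccc(Oc2ccnc3[nH]ccc23)c(F)c1`) is reported as "not active" (no number reported), so it offers no number for comparison.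

Compound 4 (`O=C(N/N=C/c1ccccc1)Nc1ccc(Oc2ccnc3[nH]ccc23)cc1`) has not yet been measured. It departs from compound 1 at one place: hydrogen in place of fluoro on an aromatic carbon. Hydrogen stands in place of fluoro on an aromatic carbon, ortho to a large group and meta to a large group.

Within the data shown here, the only measured step available as a guide is a 3.6-fold higher number from compound 1 to compound 3 (0.56 log units; beyond the scatter), which is modest but beyond the scatter. It comes from 3-bromo-4-hydroxyphenyl in place of phenyl on a carbon with a double bond to nitrogen. Among the measured compounds shown here, that is a different place in the molecule, so no measured step tests the loss of fluoro directly. For the measured compounds named here, with the modest 3.6-fold higher number from compound 1 to compound 3 (0.56 log units; beyond the scatter) as the sole guide, no step beyond the scatter is expected for this exchange in this assay, and neither direction is favoured.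

The expected step is a 1.1-fold higher number from compound 1 to compound 4 (0.05 log units; within the scatter).

For compound 4 the estimated value is 9000 nM, with an expected range from 3500 nM to 23000 nM.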

Compound 4, half-maximal inhibitory concentration: 10200 nM
For compound 4 the middle estimate is 1.1-fold (0.05 log units) below the measured one; measured number inside the range.
By their numbers in this assay, from the lowest: compounds 1 and 4 (each within the scatter of the next); then compound 3.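

In this assay, among these compounds, hydrogen in place of fluoro on an aromatic carbon gives a 1.3-fold higher number from compound 1 to compound 4 (0.11 log units; within the scatter), the first direct reading of this exchange, and the two compounds cannot be told apart. At this place on the ring, the fluoro group therefore makes no difference that this assay can detect, at least with the plain phenyl group at the other end of the molecule. Among the compounds shown here, the one step beyond the scatter in this small set, a 3.6-fold higher number from compound 1 to compound 3 (0.56 log units; beyond the scatter), comes from the 3-bromo-4-hydroxyphenyl exchange at that other end, and no measurement here offers an explanation for either result.

A single pair says nothing about whether the fluoro group would matter equally little in a compound carrying a different group at that far end, such as the 3-bromo-4-hydroxyphenyl group of compound 3. On these data alone, it also remains open whether a chloro, methyl, methoxy or amino group at this same place would stay within the scatter of compound 1 and compound 4, or would move the number in either direction.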